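Swapping an Aminoalkenyl Chain for a Larger Oxygen-Ring Amine

The compounds below may be only part of what the source reports. "The series", "measured", "known", "first", "only" and "open" are said of these compounds alone.

Measured so far:
compound 1, `NCCCCN(C[C@@H]1Cc2ncccc2CN1)[C@H]1CCCc2cccnc21`, gives 7 nm/s
compound 2, `NC/C=C/CN(C[C@H]1Cc2ncccc2CN1)[C@H]1CCCc2cccnc21`, gives 15 nm/s

Both numbers come from an ADME assay for permeability, using PAMPA, with a stated time of 4 h, at pH 7.4; a lower number here means that the compound crosses the layer more slowly, a higher number that the compound crosses the layer faster. Compound 2 stands highest of the two, and its nearest neighbour is compound 1, whose number is lower by a gap that lies beyond the usual scatter of repeated measurements. Among the measured compounds shown here, no pair of measured compounds differs in only one place, so there is no single step from which to read how one change shifts the read-out.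

Compound 3, `CN(CCCCN(C[C@H]1Cc2ncccc2CN1)[C@H]1CCCc2cccnc21)C1CCOCC1`, has not yet been measured. It differs from compound 2 in one place: a group of 11 heavy atoms (9 carbon, 1 nitrogen, 1 oxygen; one six-membered non-aromatic ring with 1 hetero atom) in place of a group of 4 heavy atoms (3 carbon, 1 nitrogen; no ring), on a saturated chain carbon bound to an amine nitrogen. The group that leaves carries one hydrogen-bond donor and no ring; the group that enters carries no hydrogen-bond donor and brings a six-membered non-aromatic ring with one hetero atom. For the measured compounds named here, with no measured step to lean on, the expectation rests on compound 2 alone. Compound 3 is expected to move upward by a 2.7-fold higher number from compound 2 to compound 3 (0.43 log units; beyond the scatter), a rise beyond the scatter. The estimate for compound 3 in this assay is 40 nm/s, with a range from 12 nm/s to 130 nm/s.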

Compound 3, apparent permeability: 490 nm/s
The estimate for compound 3 lay 12-fold (1.09 log units) below the measured number, and the stated range ends below it.
By their numbers in this assay, from the lowest: compound 1; then compound 2; then compound 3.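

In this assay, among the compounds shown here, the swap brings a 33-fold higher number from compound 2 to compound 3 (1.51 log units; beyond the scatter), so a change at this place, on a saturated chain carbon bound to an amine nitrogen, can move the read-out a long way, which the earlier compounds could not show without a step that differs in one place. The change is also a bundle: the 3-aminoprop-1-en-1-yl group leaves with its double bond and its 1 hydrogen-bond donor, and a group of 11 heavy atoms enters with a six-membered non-aromatic ring and 0 hydrogen-bond donors. Nothing measured here accounts for the rise, so it stands as an observation about this one pair.

Which part of the bundle goes with the rise stays open, as the loss of the donor, the gain in size and the arrival of the ring all come in a single step. A dimethylamino group at the same place would speak to the role of the ring, and a cyclohexyl ring in place of the oxygen-bearing ring would speak to the role of the ring oxygen.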